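Notes on an aryl-for-alkyl change in a nucleoside series

A few compounds are considered here, and "the series" means these few. Any claim that something is new, unique, unknown or untested is made for them only; others in the source may bear on it.

Compound 1 `Nc1nc(N/N=C/c2ccc(-c3ccc(Br)cc3)o2)nc2c1ncn2[C@@H]1O[C@H](CO)[C@@H](O)[C@H]1O` and compound 2 `CSCC/C=N/Nc1nc(N)c2ncn([C@@H]3O[C@H](CO)[C@@H](O)[C@H]3O)c2n1` share one core and differ in the group carried on the carbon with a double bond to nitrogen. In an assay on CHO-K1 cells for displacement of a labelled ligand from adenosine receptor A1 (Homo sapiens), read by scintillation counting, with a stated time of 60 min (on this read-out lower numbers stand for stronger inhibition and higher numbers for weaker inhibition), compound 1 gives 4.5 nM. For compound 2 only a limit is recorded in this assay, > 10000 nM. Compound 2 thus sits at the limit of > 10000 nM in this assay, at which 1 of the 2 values shown sits, and no number places it against compound 1. Compound 3 `N#Cc1ccc(/C=N/Nc2nc(N)c3ncn([C@@H]4O[C@H](CO)[C@@H](O)[C@H]4O)c3n2)cc1` is not yet measured; it differs from compound 2 by 4-cyanophenyl in place of 2-(methylsulfanyl)ethyl on a carbon with a double bond to nitrogen. Within the data shown here, no measured pair covers a change of this kind, so the expected step of an at least 33-fold lower number from compound 2 to compound 3 (1.52 log units; beyond the scatter) is toward stronger inhibition and judged well beyond the scatter. Compound 3 is expected to give 300 nM, with a range from 30 nM to 3000 nM. This expectation rests on compound 1, which carries a ring-bearing group on the carbon with a double bond to nitrogen and gives 4.5 nM.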

Compound 3, inhibition constant: 4.1 nM
The estimate for compound 3 lay 73-fold (1.86 log units) above the measured number; the measured number lies below the stated range.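

In this assay, 4-cyanophenyl in place of 2-(methylsulfanyl)ethyl on a carbon with a double bond to nitrogen gives an at least 2400-fold lower number from compound 2 to compound 3 (3.38 log units; beyond the scatter), so the group at this position can decide between strong binding and none detectable on the shared core. The size of that step is only a bound, as compound 2 carries a limit and not a number: the limit of > 10000 nM in this assay, at which 1 of the 3 values shown sits.

Compound 1 gives 4.5 nM and compound 3 gives 4.1 nM, values within the usual scatter of each other, so the single ring of 4-cyanophenyl is enough here and the ring-bearing group of compound 1 shows no edge over it.

On these data alone, whether the step belongs to the aromatic ring or to the nitrile stays open; a plain phenyl at this position would separate the two. As far as these compounds go, how a longer alkyl chain or a 4-carboxyphenyl group would read here also stays open.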